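The source may report more compounds than this note shows. Statements on the series, on what has been measured and on what is new or still open speak of the compounds shown alone.

Measured so far:
- Compound 1, `NC(=O)c1sc(-c2ccc(Cl)cc2)nc1C(Br)Br`, gives 99700 nM in an ADME assay on BHK15 cells (Mesocricetus auratus) for inhibition, read by XTT assay, with a stated time of 36 h; a lower number here means a stronger inhibitor of growth, a higher number a weaker inhibitor of growth.
- Compound 2, `CCNC(=O)c1sc(-c2ccc(Cl)cc2)nc1C(Br)Br`, gives 33300 nM.
- Compound 3, `CCSC(=O)c1sc(-c2ccc(Cl)cc2)nc1C(Br)Br`, gives 81400 nM.

Compound 1 thus stands at the highest number of the three, close to compound 3 and further from compound 2. Compound 4, `CN(C)/C=C/C(=O)c1sc(-c2ccc(Cl)cc2)nc1C(Br)Br`, differs from compound 1 in one place: 2-(dimethylamino)ethenyl in place of amino on a carbonyl carbon. Among the measured compounds shown here, two measured steps bear on this change at the same carbonyl carbon. Replacing amino with ethylsulfanyl gave a 1.2-fold lower number from compound 1 to compound 3 (0.09 log units; within the scatter), while adding ethyl on the amide-type nitrogen gave a 3.0-fold lower number from compound 1 to compound 2 (0.48 log units; beyond the scatter). Neither step matches the new group exactly, so only a small shift is expected, possibly within the scatter, or modestly lower at best. Compound 4 is therefore estimated at 50000 nM, with a range from 15000 nM to 150000 nM, meaning an expected step of a 2.0-fold lower number from compound 1 to compound 4 (0.30 log units; within the scatter).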

Compound 4, concentration for 50% growth inhibition: 38200 nM
Estimate against measurement, compound 4: 1.3-fold (0.12 log units) above; low and high end bracket the measured number.
By their numbers in this assay, from the lowest: compounds 2 and 4 (each within the scatter of the next); then compounds 3 and 1 (each within the scatter of the next).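

In this assay, placing 2-(dimethylamino)ethenyl on the carbonyl carbon in place of amino gives a 2.6-fold lower number from compound 1 to compound 4 (0.42 log units; beyond the scatter), so this position accepts a group that is not built on amino or ethylsulfanyl. The same group gives a 2.1-fold lower number from compound 3 to compound 4 (0.33 log units; beyond the scatter) when it replaces ethylsulfanyl, but a 1.1-fold higher number from compound 2 to compound 4 (0.06 log units; within the scatter) when it replaces ethylamino, which leaves it level with ethylamino. No measurement here explains these steps.

On these data alone, it remains open whether the dimethylamino end or the double bond matters for the step. A carboxylic acid or a longer amine chain at this carbonyl carbon also remains untested among the compounds shown.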